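This account rests on a few compounds, and the source may have more. Where it says the series, first, only, none or still open, it means among the compounds named here.

Measured compounds:
- compound 1 `CCCOC(=O)N[C@H](C)c1nc2ccc(F)cc2s1`, in a physicochemical assay for lipophilicity, using the shake flask method, measured as octanol-water partition, with a stated time of 15 min (on this read-out higher numbers stand for higher lipophilicity and lower numbers for lower lipophilicity), compound 1 gives 4.56
- compound 2 `C[C@@H](NC(=O)OC(C)(C)C)c1nc2ccc(F)cc2s1`, in this assay compound 2 gives 4.41

Compound 2 stands lowest of the two numbers; its nearest neighbour is compound 1, and the step of a number 0.15 log units lower from compound 1 to compound 2 (within the scatter) lies within the scatter. Compound 3 `C[C@@H](NC(=O)OCC(F)(F)F)c1nc2ccc(F)cc2s1` has not yet been measured. It differs from compound 2 in one place: 2,2,2-trifluoroethyl in place of tert-butyl on an oxygen next to a carbonyl group. Among the compounds with values here, the only measured step at this position, a number 0.15 log units lower from compound 1 to compound 2 (within the scatter), exchanged two alkyl groups and was small. No measured pair involves the 2,2,2-trifluoroethyl group, so the present change has no direct parallel among the numbers shown. On that basis the expected step of a number 0.21 log units lower from compound 2 to compound 3 (within the scatter) is small, and the range is set wide to cover the missing parallel. For compound 3 in this assay the estimate is 4.2, expected between 3.7 and 4.7.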

Compound 3, partition coefficient: 2.69
For compound 3 the middle estimate is 1.51 log units above the measured one; the measured number lies below the stated range.
By their numbers in this assay, from the lowest: compound 3; then compounds 2 and 1 (each within the scatter of the next).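

In this assay this position proves sensitive to the group on the oxygen: 2,2,2-trifluoroethyl in place of tert-butyl gives a number 1.72 log units lower from compound 2 to compound 3 (beyond the scatter), and trifluoromethyl in place of ethyl on the saturated chain carbon gives a number 1.87 log units lower from compound 1 to compound 3 (beyond the scatter). The earlier pair gave no sign of such a range, since compound 1 and compound 2, with propyl and tert-butyl, stand within the scatter of each other. Compound 3 stands apart from both by a large step, so among these three compounds the read-out at this position separates the fluorine-bearing group from the two alkyl groups.

As far as these compounds go, whether the size of the step grows with the number of fluorine atoms stays open, and 2-fluoroethyl or 2,2-difluoroethyl on the same oxygen would address that. The data shown offer nothing that accounts for the size of these steps.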